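Cytotoxicity notes on the ether-linked hexanoate series

The source may report more compounds than this note shows. Statements on the series, on what has been measured and on what is new or still open speak of the compounds shown alone.

Measured compounds:
compound 1 `CC(C)Oc1cccc(-c2ccc(C(=O)N(Cc3cccc(OCCCCCC(=O)O)c3)C(C)C)cc2)c1` — > 26000 nM
compound 2 `COc1cc(F)cc(-c2ccc(C(=O)N(Cc3cccc(OCCCCCC(=O)O)c3)C(C)C)cc2)c1` — > 26000 nM
compound 3 `CCOC(=O)CCCCCOc1ccc(CNC(C)C)cc1` — > 26000 nM

In an ADME assay on HepG2 cells (Homo sapiens) for cytotoxicity, read by CellTiter-Glo and resazurin assay, with a stated time of 72 h (on this read-out lower numbers stand for an effect already at smaller amounts and higher numbers for an effect only at larger amounts of compound), compound 1 gives > 26000 nM, which is a limit of the assay and not a number. Compound 2 likewise gives > 26000 nM, a limit. Compound 3, the parent of the step followed here, gives > 26000 nM, again a limit. All three values therefore sit at the limit of > 26000 nM in this assay, at which 3 of the 3 values shown sit, and compound 3 stands nowhere distinguishable from the other two.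

For the measured compounds named here, the only one-place step among the measured compounds, a step that the two limits leave unreadable from compound 1 to compound 2, is unreadable because both ends are limits, and it concerns the aryl substituent, not the benzylic position.

Compound 4 `CCOC(=O)CCCCCOc1ccc(CO)cc1` differs from compound 3 by hydroxy in place of isopropylamino on a saturated chain carbon bound to an aromatic carbon. Going by the values given here, no measured step bears on this change, and no readable step of any size exists in the set. The expectation for compound 4 is therefore that it, too, is reported at the limit of this assay: an estimated 30000 nM, in the range 15000 nM to 100000 nM, which would mean an expected step that the limit leaves unreadable from compound 3 to compound 4 beyond nothing readable.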

Compound 4, half-maximal effective concentration: > 27100 nM
Compound 4 was reported as a limit (the forecaster's own chance of this, stated with the estimate: 85%); the middle value lies beyond the limit too.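

In this assay compound 4 gives > 27100 nM, a limit and not a number. For the compounds shown here, compound 3 also stands at a limit, so no step from compound 3 to compound 4 can be read. The compounds shown leave open whether hydroxy in place of isopropylamino changes the effective concentration at all.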